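Working notes: carboxy to dimethylamino, compound 1 to compound 4

The source may hold more compounds than are shown below. What is called first, only, known or untested is meant among the compounds shown, and "the series" means these compounds.

Values in a toxicity assay on Huh-7.5 cells (Homo sapiens) for inhibition, read by MTT assay, with a stated time of 96 h (a lower number here means that less compound is tolerated, a higher number that more compound is tolerated), so far:
- Compound 1 `O=C(Nc1ccc(CN2CC(C(=O)O)C2)c(C(F)(F)F)c1)c1ccc(OCCCCl)c([N+](=O)[O-])c1` gives > 200000 nM as a limit of the assay, not a number
- Compound 2 `CN1CCN(Cc2ccc(NC(=O)c3ccc(OCCCCl)c(N)c3)cc2C(F)(F)F)CC1` gives 12900 nM
- Compound 3 `CCC(=O)Nc1cc(C(=O)Nc2ccc(N(C)C)cc2)ccc1OC` gives 171000 nM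

Compound 1 stands at the limit of > 200000 nM in this assay, at which 1 of the 3 values shown sits, and so has no number, only a limit. Compound 4 `CN(C)C1CN(Cc2ccc(NC(=O)c3ccc(OCCCCl)c([N+](=O)[O-])c3)cc2C(F)(F)F)C1` is not yet measured. It keeps the core of compound 1 and carries dimethylamino in place of carboxy on a saturated ring carbon. A large step down in this assay is expected, towards less compound tolerated, with compound 2 at 12900 nM taken as the guide. The estimated step is an at least 10-fold lower number from compound 1 to compound 4 (1.00 log units; beyond the scatter). Compound 4 is estimated at 20000 nM with an expected range of 7000 nM to 70000 nM.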

Compound 4, half-maximal cytotoxic concentration: 7800 nM
For compound 4 the middle estimate is 2.6-fold (0.41 log units) above the measured one; the range from low to high includes it.
By their numbers in this assay, from the lowest: compounds 4 and 2 (each within the scatter of the next); then compound 3. At a limit, above all of these: compound 1.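

In this assay, the single change from 3-carboxyazetidin-1-yl to 3-(dimethylamino)azetidin-1-yl gives an at least 25-fold lower number from compound 1 to compound 4 (1.40 log units; beyond the scatter), the only step among the compounds shown that differs in one place. This shows that the group on this saturated ring carbon can by itself shift the tolerated concentration well beyond the scatter. From the compounds shown here alone, compound 1 has only a limit of the assay, so the true size of the step stays unknown: the limit of > 200000 nM in this assay, at which 1 of the 4 values shown sits.

The compounds shown leave open whether the step follows from losing carboxy or from gaining dimethylamino. A hydroxyl or a primary amide on that ring carbon would help separate the two.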